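Swapping fluoro for trifluoromethyl on the sulfonamide ring

The source may hold more compounds than are shown below. What is called first, only, known or untested is meant among the compounds shown, and "the series" means these compounds.

Four compounds share one core and differ at two places: a substituent on the sulfonamide ring and the group on the oxygen of the other aryl ring. Compound 1 `COc1cc(-c2nc(-c3ccccc3)[nH]c2-c2ccnc(NCCCNS(=O)(=O)c3ccc(F)cc3)n2)ccc1F` carries a fluoro on the sulfonamide ring and a methoxy on the core. In a functional assay on LOX IMVI cells (Homo sapiens) for cytotoxicity, read by MTT assay, with a stated time of 24 h (a lower number here means a stronger inhibitor, a higher number a weaker inhibitor), compound 1 gives 3960 nM. Compound 2 `COc1cc(-c2nc(-c3ccccc3)[nH]c2-c2ccnc(NCCCNS(=O)(=O)c3ccc(C(F)(F)F)cc3)n2)ccc1F` differs from compound 1 by trifluoromethyl in place of fluoro on an aromatic carbon, and in this assay compound 2 gives 75200 nM, so that a 19-fold higher number from compound 1 to compound 2 (1.28 log units; beyond the scatter). Compound 3 `O=S(=O)(NCCCNc1nccc(-c2[nH]c(-c3ccccc3)nc2-c2ccc(F)c(O)c2)n1)c1ccc(F)cc1` differs from compound 1 by hydrogen in place of methyl on an oxygen on an aromatic ring, and in this assay compound 3 gives 19200 nM, which is a 4.8-fold higher number from compound 1 to compound 3 (0.69 log units; beyond the scatter).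

Compound 4 `O=S(=O)(NCCCNc1nccc(-c2[nH]c(-c3ccccc3)nc2-c2ccc(F)c(O)c2)n1)c1ccc(C(F)(F)F)cc1` is not yet measured. It differs from compound 3 by trifluoromethyl in place of fluoro on an aromatic carbon, the same change as from compound 1 to compound 2, at the same place. The two cores differ only in the way just described for compound 1 and compound 3. Among the measured compounds shown here, since the change from compound 1 to compound 2 produced a large weakening, a similar large weakening is expected in this assay from compound 3 to compound 4, namely a 13-fold higher number from compound 3 to compound 4 (1.11 log units; beyond the scatter), because it rests on the single step of a 19-fold higher number from compound 1 to compound 2 (1.28 log units; beyond the scatter). The number may approach the top of the tested range. Compound 4 is therefore estimated to give about 250000 nM in this assay, with a plausible range from 60000 nM to 800000 nM.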

Compound 4, half-maximal inhibitory concentration: 2450 nM
For compound 4 the middle estimate is 100-fold (2.01 log units) above the measured one; the whole stated range lies above it.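

In this assay, the swap of fluoro for trifluoromethyl gives a 7.8-fold lower number from compound 3 to compound 4 (0.89 log units; beyond the scatter) on the core with the hydroxy, a fall in the number where the core with the methoxy showed a rise, so this change does not carry from one core to the other: the same change on two cores in this assay, a 19-fold higher number (1.28 log units; beyond the scatter) from compound 1 to compound 2 and a 7.8-fold lower number (0.89 log units; beyond the scatter) from compound 3 to compound 4, 150-fold (2.17 log units) apart, beyond the scatter of two such steps

Read the other way, replacing the methyl on the oxygen with hydrogen gives a 31-fold lower number from compound 2 to compound 4 (1.49 log units; beyond the scatter) when trifluoromethyl sits on the sulfonamide ring, while with fluoro there the number rose, so the effect at each place depends on what sits at the other: the same change on two cores in this assay, a 4.8-fold higher number (0.69 log units; beyond the scatter) from compound 1 to compound 3 and a 31-fold lower number (1.49 log units; beyond the scatter) from compound 2 to compound 4, 150-fold (2.17 log units) apart, beyond the scatter of two such steps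

In these four compounds, then, a step measured on one core is a poor guide to the same step on the other, but the data do not show why, and with a single pair for each change they do not show that this reversal extends to other groups.

The compounds shown leave open whether another group on the sulfonamide ring, such as chloro or a nitrile, would behave like fluoro or like trifluoromethyl on each core. They also leave open how an ethyl group on the oxygen, or a longer chain in place of the present one, would fit this picture.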